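Extending the oxane linker by one methylene

This account rests on a few compounds, and the source may have more. Where it says the series, first, only, none or still open, it means among the compounds named here.

Measured so far:
compound 1 `CO[C@H]1CC[C@@H](CNc2cc(NCc3cnccc3C(F)(F)F)ncc2C#N)CC1` — 5000 nM
compound 2 `N#Cc1cnc(NCc2cnccc2C(F)(F)F)cc1NC1CCOCC1` — 9800 nM

In an assay on isolated protein for inhibition of protein kinase C delta type (Homo sapiens), read by TR-FRET, with a stated time of 2 h (on this read-out lower numbers stand for stronger inhibition and higher numbers for weaker inhibition), compound 2 gives 9800 nM, the higher of the two numbers seen, while compound 1 gives 5000 nM; the step of a 2.0-fold higher number from compound 1 to compound 2 (0.29 log units; within the scatter) stays within the scatter, so the two compounds cannot be separated on these data. Compound 3 `N#Cc1cnc(NCc2cnccc2C(F)(F)F)cc1NCC1CCOCC1` differs from compound 2 in one place: (oxan-4-yl)methyl in place of oxan-4-yl on a nitrogen on an aromatic ring. Within the data shown here, only one measured step bears on this change, a 2.0-fold higher number from compound 1 to compound 2 (0.29 log units; within the scatter), in which a ring carried on a methyl was exchanged for a ring bound directly to the nitrogen, and the number moved by an amount inside the scatter. Going back from a directly bound ring to one carried on a methyl is therefore expected to move the number little, if at all. For compound 3 the estimate is 6500 nM (range 2200 nM to 20000 nM), a step of a 1.5-fold lower number from compound 2 to compound 3 (0.18 log units; within the scatter) that is expected to remain within the scatter.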

Compound 3, half-maximal inhibitory concentration: 5000 nM
For compound 3 the middle estimate is 1.3-fold (0.11 log units) above the measured one; the range from low to high includes it.
By their numbers in this assay, from the lowest: compounds 1, 3 and 2 (each within the scatter of the next).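

In this assay, lengthening the oxan-4-yl group on the nitrogen to (oxan-4-yl)methyl gives a 2.0-fold lower number from compound 2 to compound 3 (0.29 log units; within the scatter), so this added methylene cannot be told apart from the shorter linker on these data. With the methyl linker kept, oxan-4-yl in place of 4-methoxycyclohexyl on the saturated chain carbon gives no change at the digits printed from compound 1 to compound 3 (within the scatter), so the ring exchange at this place also cannot be resolved, and none of the three groups can be separated from the others. Nothing measured here bears on why these changes leave the numbers so close.

Each of the three groups holds a saturated ring and an oxygen, so the compounds shown leave open how this place would respond to a different kind of group. An amine, a carboxylic acid or a longer chain on the same nitrogen would test whether the number can move beyond the scatter.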